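The compounds below may be only part of what the source reports. "The series", "measured", "known", "first", "only" and "open" are said of these compounds alone.

Measured in a functional assay on PC-3 cells (Homo sapiens) for antiproliferative activity, read by MTT assay, with a stated time of 72 h; on this read-out lower numbers stand for stronger inhibition and higher numbers for weaker inhibition:
- compound 1 `CCN(CC)C(=S)SCC1=CCOC1=O`: 57100 nM
- compound 2 `Cc1ccc(NC(=S)SCC2=CCOC2=O)cc1`: 93500 nM

Compound 1 has only compound 2 for comparison, and the two values lie within the usual scatter of each other, so no order can be read between them. The next compound to be measured is compound 3 `O=C1OCC=C1CSC(=S)NC1CC1`, with cyclopropylamino in place of diethylamino on a thiocarbonyl carbon. For the measured compounds named here, no measured step in this assay shows what a single change does. With only these two values as a guide, no shift beyond the scatter is expected, and no firm direction. The estimated change is a 1.2-fold higher number from compound 1 to compound 3 (0.09 log units; within the scatter). For compound 3 the expected value is 70000 nM, with an estimated range from 30000 nM to 150000 nM.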

Compound 3, half-maximal inhibitory concentration: 117000 nM
Compound 3: middle estimate off by 1.7-fold (0.22 log units), on the low side, and the stated range covers the measured number.
By their numbers in this assay, from the lowest: compounds 1, 2 and 3 (each within the scatter of the next, the first and the last beyond it).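

In this assay, the thiocarbonyl carbon now has its first measured single change: cyclopropylamino in place of diethylamino gives a 2.0-fold higher number from compound 1 to compound 3 (0.31 log units; beyond the scatter), a modest loss of inhibition. The group at this position can therefore move the read-out, though the step only just clears the usual scatter. The change brings in a ring and a hydrogen-bond donor together with one heavy atom fewer, and nothing measured here assigns the step to any of these differences or gives it a cause.

Open, from the compounds shown here alone, is whether the ring or the hydrogen on the nitrogen goes with the step, which ethylamino, without a ring but with that hydrogen, and pyrrolidin-1-yl, with a ring but without it, could separate. Also open, going by these compounds, is whether morpholin-4-yl at this position would move the value in either direction.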